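Aryl variation on the ring nitrogen: compound 3 expected

The source may report more compounds than this note shows. Statements on the series, on what has been measured and on what is new or still open speak of the compounds shown alone.

Measured so far:
compound 1, `CCc1ccccc1-n1nncc1CN1C(=O)C2(C(C#N)=C(N)Oc3c(N)cc4nc5ccccc5nc4c32)c2ccccc21`, 17900 nM
compound 2, `Cc1ccc(-n2nncc2CN2C(=O)C3(C(C#N)=C(N)Oc4c(N)cc5nc6ccccc6nc5c43)c3ccccc32)cc1Cl`, > 50000 nM
to be measured: compound 3, `N#CC1=C(N)Oc2c(N)cc3nc4ccccc4nc3c2C12C(=O)N(Cc1cnnn1-c1c(Cl)cc(Cl)cc1Cl)c1ccccc12`

In a functional assay on HepG2 cells (Homo sapiens) for antiproliferative activity, read by MTT assay, with a stated time of 48 h (on this read-out lower numbers stand for stronger inhibition and higher numbers for weaker inhibition), compound 1 gives 17900 nM. Compound 2 gives no number in this assay, only a limit, > 50000 nM. Within the data shown here, the one measured step, an at least 2.7-fold higher number from compound 1 to compound 2 (0.44 log units; beyond the scatter), therefore ends at the assay ceiling (the limit of > 50000 nM in this assay, at which 1 of the 2 values shown sits), and compound 2 stands at that ceiling with its true value unknown beyond it.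

Compound 3 carries 2,4,6-trichlorophenyl in place of 3-chloro-4-methylphenyl on an aromatic nitrogen. Among the measured compounds shown here, the only step that bears on it is the exchange of one aryl group for another on the same ring nitrogen, an at least 2.7-fold higher number from compound 1 to compound 2 (0.44 log units; beyond the scatter), which lowered activity at least modestly. For the measured compounds named here, no step starts from compound 2 itself, so the direction of a further aryl change is open. Compound 3 is expected to remain near the ceiling, estimated at 45000 nM, range 15000 nM to 120000 nM. The expected step of an at least 1.1-fold lower number from compound 2 to compound 3 (0.04 log units; that floor lies within the scatter) is therefore none beyond the scatter, most likely again reported as a limit.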

Compound 3, half-maximal inhibitory concentration: 37800 nM
Beside the measured number, compound 3's estimate is 1.2-fold (0.08 log units) above it; the range from low to high includes it.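

Replacing 2-ethylphenyl with 2,4,6-trichlorophenyl on the aromatic nitrogen in this assay gives a 2.1-fold higher number from compound 1 to compound 3 (0.32 log units; beyond the scatter) and puts a measured size on a loss of activity between two aryl groups at this position. The remaining step, an at least 1.3-fold lower number from compound 2 to compound 3 (0.12 log units; that floor lies within the scatter) and with only a floor, gives no order between 3-chloro-4-methylphenyl and 2,4,6-trichlorophenyl. Compound 2 has only a limit and not a number: the limit of > 50000 nM in this assay, at which 1 of the 3 values shown sits.

Among the three aryl groups shown, 2-ethylphenyl gives the lowest number, but whether that reflects the ethyl group itself remains open. A plain phenyl, a phenyl carrying an amine or a carboxylic acid, or a pyridine ring on the same nitrogen would show whether any aryl group here goes below the number of compound 1.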